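Methylating a free hydroxy on two different cores

The compounds below may be only part of what the source reports. "The series", "measured", "known", "first", "only" and "open" are said of these compounds alone.

Measured so far in a functional assay on PC-3 cells (Homo sapiens) for antiproliferative activity, with a stated time of 72 h; on this read-out higher numbers stand for weaker inhibition and lower numbers for stronger inhibition:
compound 1, `COC(=O)CN(C)Cc1c(OC)cc(OC)c(C(=O)/C=C/c2ccccc2Cl)c1O`: 7200 nM
compound 2, `COc1cc(OC)c(C(=O)/C=C/c2ccccc2Cl)c(O)c1CN(C)CC(=O)O`: 12500 nM
compound 3, `COc1cc(O)c2c(=O)cc(-c3ccccc3Cl)oc2c1CN1CCCCC1`: 63400 nM

Compounds 1 and 2 share one core; compound 3 has another, and the difference between the two cores is not broken down here. Compound 3 gives the highest number of the three in this assay, and its gap to compound 2 and to compound 1 lies beyond the scatter.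

Within the first core, compound 2 to compound 1 is methyl in place of hydrogen on an oxygen next to a carbonyl group; the step is a 1.7-fold lower number from compound 2 to compound 1 (0.24 log units; within the scatter), so no real change follows from it.

Compound 4, `COc1cc(OC)c2c(=O)cc(-c3ccccc3Cl)oc2c1CN1CCCCC1`, not yet measured, arises from compound 3 by methyl in place of hydrogen on an oxygen on an aromatic ring. This is the same kind of change as compound 2 to compound 1, but not the same: there the oxygen sat next to a carbonyl group whose other neighbour is a carbonyl carbon, here it sits on an aromatic ring whose other neighbour is an aromatic carbon. For the measured compounds named here, only one earlier instance exists, on another core and another kind of oxygen, so the expectation rests weakly on it.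

Given that precedent, the step from compound 3 to compound 4 in this assay is expected to be small, roughly a 1.1-fold higher number from compound 3 to compound 4 (0.04 log units; within the scatter), because compound 2 to compound 1 gave a 1.7-fold lower number from compound 2 to compound 1 (0.24 log units; within the scatter). Compound 4 is estimated at 70000 nM, within 25000 nM to 200000 nM.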

Compound 4, half-maximal inhibitory concentration: 15500 nM
For compound 4 the middle estimate is 4.5-fold (0.65 log units) above the measured one; the whole stated range lies above it.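

In this assay, methyl in place of hydrogen on an oxygen on an aromatic ring gives a 4.1-fold lower number from compound 3 to compound 4 (0.61 log units; beyond the scatter), a step that lies beyond the scatter, whereas the earlier step on the other core stayed within it. Set side by side, the two steps cannot be told apart: the same change on two cores in this assay, a 1.7-fold lower number (0.24 log units; within the scatter) from compound 2 to compound 1 and a 4.1-fold lower number (0.61 log units; beyond the scatter) from compound 3 to compound 4, 2.4-fold (0.37 log units) apart, within the scatter of two such steps

The change can therefore be carried between these two cores without a measurable difference in the size of its step, although the oxygens it acts on are of different kinds. This does not show that the step is the same on both cores, since a real difference smaller than the scatter of two such steps would go unseen, and a single pair on each core says nothing about any further core.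

Open, on these data alone, is whether a longer chain such as ethyl in place of the methyl on that oxygen would give a step of similar size on either core. Also open, as far as these compounds go, is how an amine in place of the hydroxy would compare.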